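Cyclohexyl for 2-cyclohexylethyl at the assay limit

The source may hold more compounds than are shown below. What is called first, only, known or untested is meant among the compounds shown, and "the series" means these compounds.

Measured in an ADME assay on P388D1 cells (Mus musculus) for cytotoxicity, read by fluorescence and resazurin assay, with a stated time of 72 h; a higher number here means a weaker inhibitor, a lower number a stronger inhibitor (both entries are limits):
compound 1 `O=C(CCC1CCCCC1)Nc1ncc(Cc2cccc3sccc23)s1` gives > 40000 nM (a limit)
compound 2 `O=C(c1cnc(NC(=O)C2CCCCC2)s1)c1cccc2ccccc12` gives > 40000 nM (a limit)

In this assay compound 1 stands at > 40000 nM (a limit, not a number). Compound 2 shares that position, so the two cannot be ranked (the limit of > 40000 nM in this assay, at which 2 of the 2 values shown sit).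

Compound 3 `O=C(Nc1ncc(Cc2cccc3sccc23)s1)C1CCCCC1` keeps the core of compound 1 and carries cyclohexyl in place of 2-cyclohexylethyl on a carbonyl carbon. For the measured compounds named here, no measured pair shows this change, and neither measured compound offers a number to step from. In this assay no step beyond the scatter is expected. That expectation rests on compound 1, which gives > 40000 nM (again a limit). The estimated change is a number no higher from compound 1 to compound 3 (the limit leaves the size open) (expected to stay within the scatter). For compound 3 the expected value is 40000 nM (estimated range 15000 nM to 40000 nM), and a report as a limit only is the likelier outcome.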

Compound 3, half-maximal inhibitory concentration: > 40000 nM
Compound 3 was reported as a limit; the forecaster's own chance of this, stated with the estimate: 80%; the middle value lies on the limit itself.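

In this assay compound 3 gives > 40000 nM, a limit and not a number. No step from compound 1 to compound 3 can be read, because all the values sit at one limit: the limit of > 40000 nM in this assay, at which 3 of the 3 values shown sit.

The compounds shown leave open whether cyclohexyl and 2-cyclohexylethyl on a carbonyl carbon differ at all in this assay.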